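The source may report more compounds than this note shows. Statements on the series, on what has been measured and on what is new or still open speak of the compounds shown alone.

Measured so far in an ADME assay on HCT-116 cells (Homo sapiens) for antiproliferative activity (a higher number here means a weaker inhibitor, a lower number a stronger inhibitor), are these compounds
compound 1 `COc1ccc(C(N)=O)cc1/C=C/c1ccc(Cl)cc1` gives 7100 nM
compound 2 `COc1ccc(C(N)=O)cc1/C=C/c1ccc(C)cc1` gives 48000 nM
compound 3 `COc1ccc(C(N)=O)cc1/C=C/c1ccc(C#N)cc1` gives 16000 nM

Compound 3 at 16000 nM holds the middle place, the second highest of the three numbers, with compound 1 lower and compound 2 higher. The next structure is compound 4 `COc1ccc(/C=C/c2cc(C(N)=O)ccc2OC)cc1` which carries methoxy in place of cyano on an aromatic carbon with the rest of the structure unchanged. For the measured compounds named here, no measured compound carries methoxy at this place, so the evidence is indirect. Three measured steps exchange the group at this same place. They are a 2.3-fold higher number from compound 1 to compound 3 (0.35 log units; beyond the scatter) and a 3.0-fold lower number from compound 2 to compound 3 (0.48 log units; beyond the scatter) and a 6.8-fold higher number from compound 1 to compound 2 (0.83 log units; beyond the scatter) and all three are modest, though beyond the scatter. Among these three compounds the number moves without large jumps, but the steps give no rule for methoxy. A modest change at most is therefore expected in this assay with no firm direction. Any estimate must stay wide enough to reach the values of compound 1 and compound 2. The expected move is a 1.3-fold higher number from compound 3 to compound 4 (0.10 log units; within the scatter) which would not go beyond the scatter. For compound 4 the estimated value is 20000 nM with 6000 nM to 60000 nM as its expected range.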

Compound 4, half-maximal inhibitory concentration: 19000 nM
Compound 4: the middle estimate sits 1.1-fold (0.02 log units) above what was measured; measured number inside the range.
By their numbers in this assay, from the lowest: compound 1; then compounds 3 and 4 (each within the scatter of the next); then compound 2.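

In this assay, methoxy in place of cyano on this aromatic carbon gives a 1.2-fold higher number from compound 3 to compound 4 (0.07 log units; within the scatter) and so shows that these two groups, which match in heavy atoms and hydrogen-bond acceptors, cannot be told apart at this place. Methoxy does part from the other two groups, with a 2.5-fold lower number from compound 2 to compound 4 (0.40 log units; beyond the scatter) when it replaces methyl and a 2.7-fold higher number from compound 1 to compound 4 (0.43 log units; beyond the scatter) when it replaces chloro. Among these four compounds, compound 1 with chloro therefore remains the strongest inhibitor and compound 2 with methyl the weakest, while compound 3 and compound 4 share the middle and a fourth group at this place has not widened the span of the numbers.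

On these data alone, whether an amine, a carboxylic acid or a longer chain such as butoxy at this place would stay inside that span or leave it remains open. Nothing measured here accounts for the order of the four groups at this place.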